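The source may report more compounds than this note shows. Statements on the series, on what has been measured and on what is new or still open speak of the compounds shown alone.

Working notes on the series. The shared core of compound 1 `O=C(CN1CCN(c2cccc(F)c2)CC1)Nc1nc2c(s1)CCCC2` carries an aryl piperazine on the amine side and a fused saturated ring on the heterocycle side, and it is tested in an assay on isolated protein for inhibition of long-chain fatty acid transport protein 1 (Homo sapiens), read by scintillation counting, with a stated time of 20 min; on this read-out lower numbers stand for stronger inhibition and higher numbers for weaker inhibition. In this assay compound 1 returns only a limit, > 1000 nM, so its place on the scale is not a number but the ceiling at which the record stops (the limit of > 1000 nM in this assay, at which 1 of the 3 values shown sits). Among the measured compounds shown here, two further members differ from compound 1 in more than one place, so no single step links them to it. Compound 2 `O=C(CN1CCN(c2ccc(F)cc2)CC1)Nc1nc2c(s1)CCC2` gives 490 nM in this assay. Compound 3 `O=C(CN1CCN(c2ccc(F)cc2)CC1)Nc1nc2c(s1)CCCCC2` gives 120 nM in this assay. Both carry a fluorine at the 4-position of the phenyl rather than the 3-position, and both differ from compound 1 in the size of the saturated ring, so what their values show is only that such variants fall inside the measurable range.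

Compound 4 `Cc1ccc(N2CCN(CC(=O)Nc3nc4c(s3)CCCC4)CC2)cc1` is not yet measured. It differs from compound 1 by 4-methylphenyl in place of 3-fluorophenyl on an amine nitrogen in a ring. For the measured compounds named here, with no measured step of this kind available, the step from compound 1 to compound 4 is expected to be modest and toward stronger inhibition, an at least 1.4-fold lower number from compound 1 to compound 4 (0.15 log units; that floor lies within the scatter), reflecting only that compound 1 sits at the limit. For compound 4 the estimate in this assay is 700 nM, within a range from 200 nM to 3000 nM.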

Compound 4, half-maximal inhibitory concentration: 250 nM
Beside the measured number, compound 4's estimate is 2.8-fold (0.45 log units) above it; the range from low to high includes it.
By their numbers in this assay, from the lowest: compound 3; then compounds 4 and 2 (each within the scatter of the next). At a limit, above all of these: compound 1.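

In this assay, among the compounds shown here, 4-methylphenyl in place of 3-fluorophenyl on an amine nitrogen in a ring gives the only step that can be read at a single place, an at least 4.0-fold lower number from compound 1 to compound 4 (0.60 log units; beyond the scatter), with the rest of the structure unchanged. The earlier compounds shown here differed from compound 1 in more than one place and so could not tie any change in the number to this position; this step shows that a change on the aryl group alone, with the saturated ring size held, is enough to bring the number down from the ceiling and beyond the scatter. The size of the step is a floor and not a measured distance, because one end of it is a limit: the limit of > 1000 nM in this assay, at which 1 of the 4 values shown sits.

The step changes the group and its place on the phenyl together, so 3-methylphenyl and 4-fluorophenyl on the core of compound 1 would be needed to say how much of it belongs to each. Also open, from the compounds shown here alone, is how a 4-methoxyphenyl, or a phenyl bearing an amine or a carboxylic acid, would read at this position.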